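Chloro-to-fluoro swap on the aryl ring of compound 2

The source may report more compounds than this note shows. Statements on the series, on what has been measured and on what is new or still open speak of the compounds shown alone.

Two members of this series have numbers in an assay for inhibition of kynurenine 3-monooxygenase (Rattus norvegicus); a higher number here means a weaker inhibitor, a lower number a stronger inhibitor. Compound 1 `COC(=O)C(=O)/C=C(\O)c1cccc(F)c1F` gives 8100 nM in this assay, and compound 2 `COC(=O)C(=O)/C=C(\O)c1ccc(Cl)c(Cl)c1` gives 1900 nM, the lowest of the two and beyond the scatter of compound 1. Compound 3 `COC(=O)C(=O)/C=C(\O)c1ccc(F)c(Cl)c1` is not yet measured and differs from compound 2 by fluoro in place of chloro on an aromatic carbon. Within the data shown here, no measured pair shows this exact change, so no step size can be read from the data. The expectation is a modest rise in this assay, a step from compound 2 to compound 3 of about a 1.8-fold higher number from compound 2 to compound 3 (0.27 log units; within the scatter), near the edge of the scatter. For compound 3 the estimate in this assay is 3500 nM, with a range from 1500 nM to 8000 nM.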

Compound 3, half-maximal inhibitory concentration: 2600 nM
Beside the measured number, compound 3's estimate is 1.3-fold (0.13 log units) above it, and the stated range covers the measured number.
By their numbers in this assay, from the lowest: compounds 2 and 3 (each within the scatter of the next); then compound 1.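

The swap of fluoro in place of chloro, on the aromatic carbon para to a group of 9 heavy atoms and ortho to a chloro group, gives a 1.4-fold higher number from compound 2 to compound 3 (0.14 log units; within the scatter) in this assay, the first single-place step available in the series. At this position, chloro and fluoro are therefore not told apart by this read-out, and the change leaves the number within the scatter. No accompanying measurement offers an explanation for this result.

Whether this carbon needs a halogen at all remains open, as the compounds shown carry none of hydrogen, methoxy or an amine there. On these data alone, how the methyl ester contributes is also open, and a carboxylic acid in its place would address that question.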